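From the limit to an aryl group on nitrogen

The source may report more compounds than this note shows. Statements on the series, on what has been measured and on what is new or still open speak of the compounds shown alone.

Compound 1 `CCn1ccnc1-c1cc(OC)c(OC)c(OC)c1`: > 100000 nM
Compound 2 `CCCn1ccnc1-c1cc(OC)c(OC)c(OC)c1`: > 100000 nM

In a functional assay on MDA-MB-468 cells (Homo sapiens) for antiproliferative activity, read by MTT assay, with a stated time of 72 h (on this read-out lower numbers stand for stronger inhibition and higher numbers for weaker inhibition), compound 1 stands at the limit of > 100000 nM in this assay, at which 2 of the 2 values shown sit, so it has a limit and no number. Compound 3 `COc1cc(-c2nccn2-c2cccc(C)c2)cc(OC)c1OC` carries 3-methylphenyl in place of ethyl on an aromatic nitrogen. Among the measured compounds shown here, the only measured step bearing on this change is a step that the two limits leave unreadable from compound 1 to compound 2, which also concerns the group on that nitrogen but gives no size to carry over. For the measured compounds named here, with the limit of compound 1 at > 100000 nM, only a step toward stronger inhibition could be read, so that direction is expected, though no measured step supports its size. The expected step, a loosely estimated one, is an at least 20-fold lower number from compound 1 to compound 3 (1.30 log units; beyond the scatter). For compound 3 the estimate is 5000 nM, with an expected range from 300 nM to 80000 nM.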

Compound 3, half-maximal inhibitory concentration: 22600 nM
For compound 3 the middle estimate is 4.5-fold (0.66 log units) below the measured one; measured number inside the range.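

In this assay, among the compounds shown here, putting an aryl group on this aromatic nitrogen yields the first number: 3-methylphenyl in place of ethyl gives an at least 4.4-fold lower number from compound 1 to compound 3 (0.64 log units; beyond the scatter), and 3-methylphenyl in place of propyl gives an at least 4.4-fold lower number from compound 2 to compound 3 (0.64 log units; beyond the scatter). The step between the two alkyl compounds cannot be read, whereas these two steps show that the group on this nitrogen can move the read-out beyond the scatter. Both steps give only a minimum size, with compound 1 and compound 2 each resting at a limit and not a number: the limit of > 100000 nM in this assay, at which 2 of the 3 values shown sit.

The compounds shown leave open whether the aromatic ring alone accounts for the step or its methyl also contributes, which a plain phenyl or a benzyl group on the same nitrogen would address. Also open, from the compounds shown here alone, is how an amine or a carboxylic acid on that ring would read.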